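Shortening a long amide chain on an acetylated sugar core

The compounds below may be only part of what the source reports. "The series", "measured", "known", "first", "only" and "open" are said of these compounds alone.

Measured compounds:
- compound 1, `CCCCCCCCCCCCCCCCCC(=O)Nc1nnc(S[C@@H]2O[C@H](COC(C)=O)[C@H](OC(C)=O)[C@H](OC(C)=O)[C@H]2OC(C)=O)s1`: 97500 nM
- compound 2, `CCCCCCCCCCCC(=O)Nc1nnc(S[C@@H]2O[C@H](CO)[C@H](O)[C@H](O)[C@H]2O)s1`: 8700 nM
- compound 3, `CCCCCCCC(=O)Nc1nnc(S[C@@H]2O[C@H](CO)[C@H](O)[C@H](O)[C@H]2O)s1`: 50800 nM

In a functional assay on HeLa cells (Homo sapiens) for cytotoxicity, read by MTT assay, with a stated time of 24 h (on this read-out higher numbers stand for weaker inhibition and lower numbers for stronger inhibition), compound 1 gives the highest of the three numbers. Its value sits close to that of compound 3, which gives 50800 nM, a gap that lies within the usual scatter; compound 2, at 8700 nM, stands clearly lower than compound 1, a gap beyond the scatter.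

Compound 4, `CCCCCCCCCC(=O)Nc1nnc(S[C@@H]2O[C@H](COC(C)=O)[C@H](OC(C)=O)[C@H](OC(C)=O)[C@H]2OC(C)=O)s1`, has not yet been measured. It differs from compound 1 in one place: hydrogen in place of octyl on a saturated chain carbon, nine bonds along the chain from a carbonyl carbon.

Within the data shown here, only one measured step speaks to chain length: a 5.8-fold higher number from compound 2 to compound 3 (0.77 log units; beyond the scatter), a modest weakening when the chain is cut short on the sugar core without acetyl groups. The change from compound 1 to compound 4 removes a larger piece of chain but starts from a much longer chain, and compound 1 is already the weakest number recorded, so the measured step gives only a loose guide.

Compound 4 is expected to land near compound 1, with a step of a 1.2-fold lower number from compound 1 to compound 4 (0.09 log units; within the scatter) in this assay that need not exceed the scatter. The estimate for compound 4 is 80000 nM, within a range of 20000 nM to 250000 nM.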

Compound 4, half-maximal inhibitory concentration: 44900 nM
The estimate for compound 4 lay 1.8-fold (0.25 log units) above the measured number; the range from low to high includes it.
By their numbers in this assay, from the lowest: compound 2; then compounds 4, 3 and 1 (each within the scatter of the next, the first and the last beyond it).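

Among these compounds, removing octyl from the saturated chain carbon nine bonds along the chain from a carbonyl carbon gives a 2.2-fold lower number from compound 1 to compound 4 (0.34 log units; beyond the scatter) in this assay, the first measured chain-shortening step on the acetylated core, and it lies beyond the scatter. This step runs the opposite way from a 5.8-fold higher number from compound 2 to compound 3 (0.77 log units; beyond the scatter), which removes butyl on the core without acetyl groups, so among these compounds, shortening the chain does not always give a higher number. The two steps start from different chain lengths and sit on different cores, and no measurement shown explains why their directions differ.

No pair shown differs only in the acetyl groups, so what those groups do at a fixed chain length remains open. On these data alone, it is also open how the number would move on the acetylated core with a chain shorter than that of compound 4, or with an amine or a carboxylic acid at the far end of the chain.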